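This account rests on a few compounds, and the source may have more. Where it says the series, first, only, none or still open, it means among the compounds named here.

Measured compounds:
compound 1 `COc1ccccc1NC(=O)CCC(=O)OCCCCCCSc1ccc([N+](=O)[O-])c2nonc12` — 280 nM
compound 2 `Cc1ccc(NC(=O)CCC(=O)OCCCCCCSc2ccc([N+](=O)[O-])c3nonc23)cc1` — 390 nM

Both numbers come from an assay on isolated protein for inhibition of glutathione S-transferase Mu 2 (Homo sapiens), with a stated time of 10 min; on this read-out lower numbers stand for stronger inhibition and higher numbers for weaker inhibition. The step of a 1.4-fold higher number from compound 1 to compound 2 (0.14 log units; within the scatter) is within the scatter, so compound 2 and compound 1 cannot be told apart on this read-out; the two values of the series simply sit together.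

Compound 3 `O=C(CCC(=O)OCCCCCCSc1ccc([N+](=O)[O-])c2nonc12)Nc1ccc(C(F)(F)F)cc1` has not been measured. It differs from compound 2 by trifluoromethyl in place of methyl on an aromatic carbon. Among the compounds with values here, the only measured step that touches this region of the molecule is a 1.4-fold higher number from compound 1 to compound 2 (0.14 log units; within the scatter), which exchanged one substituted phenyl on the amide-type nitrogen for another and did not move the number beyond the scatter. Nothing measured here reports a trifluoromethyl, or any substituent with fluorine, on this phenyl. The expectation therefore rests on a single step, and that step shows no change; the estimate for the step from compound 2 to compound 3 is a 1.0-fold higher number from compound 2 to compound 3 (0.01 log units; within the scatter), with a range wide enough to admit a shift in either direction.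

On this basis compound 3 is estimated at 400 nM in this assay, expected between 150 nM and 1100 nM.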

Compound 3, half-maximal inhibitory concentration: 90 nM
For compound 3 the middle estimate is 4.4-fold (0.65 log units) above the measured one; measured number below the stated range.
By their numbers in this assay, from the lowest: compound 3; then compounds 1 and 2 (each within the scatter of the next).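

Working notes on the series. In this assay, the phenyl carbon para to a large group responds to substitution: trifluoromethyl in place of methyl gives a 4.3-fold lower number from compound 2 to compound 3 (0.64 log units; beyond the scatter), whereas the earlier exchange of one substituted phenyl for another gave only a 1.4-fold higher number from compound 1 to compound 2 (0.14 log units; within the scatter) and showed no movement. The 4-(trifluoromethyl)phenyl group also stands apart from the 2-methoxyphenyl group, with a 3.1-fold lower number from compound 1 to compound 3 (0.49 log units; beyond the scatter), so compound 3 is the strongest of the three on this read-out, by modest steps beyond the scatter. Nothing on hand bears on the reason for this lower number.

The compounds shown leave open whether the lower number belongs to trifluoromethyl alone or also comes with a chlorine, a nitrile or a carboxylic acid on that same carbon. They also leave open how a plain phenyl compares with these three, and whether trifluoromethyl gives a similar step at other carbons of the ring or with a longer chain in place of the present one.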